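From 4-fluorophenyl to 2-phenylethenyl on a shared core

The source may report more compounds than this note shows. Statements on the series, on what has been measured and on what is new or still open speak of the compounds shown alone.

Measured in a functional assay on CAPAN-1 cells (Homo sapiens) for antiproliferative activity, with a stated time of 72 h; on this read-out lower numbers stand for stronger inhibition and higher numbers for weaker inhibition:
- Compound 1 `CCCC#Cc1cc([C@@H]2O[C@H](CO)[C@@H](O)[C@H]2O)n2ncnc(N)c12`: 20 nM
- Compound 2 `Nc1ncnn2c([C@@H]3O[C@H](CO)[C@@H](O)[C@H]3O)cc(-c3ccccc3)c12`: 65200 nM
- Compound 3 `Nc1ncnn2c([C@@H]3O[C@H](CO)[C@@H](O)[C@H]3O)cc(-c3ccc(F)cc3)c12`: 65600 nM

Compound 3 sits at the weak end of this small set, level with compound 2: the data show a 1.0-fold higher number from compound 2 to compound 3 (0.00 log units; within the scatter). Compound 1 lies far from it, with a 3300-fold higher number from compound 1 to compound 3 (3.52 log units; beyond the scatter).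

Compound 4 `Nc1ncnn2c([C@@H]3O[C@H](CO)[C@@H](O)[C@H]3O)cc(/C=C/c3ccccc3)c12` carries 2-phenylethenyl in place of 4-fluorophenyl on an aromatic carbon. The same place gave the large change of a 3300-fold higher number from compound 1 to compound 2 (3.51 log units; beyond the scatter), so swapping groups here can matter greatly. Going by the values given here, the new group keeps the carbon-only aromatic ring of compound 2 and compound 3, but adds a double bond outside that ring, which no measured compound has. A moderate move toward lower numbers in this assay therefore seems likely, stopping well short of compound 1, though with much uncertainty.

The expected change is a 5.5-fold lower number from compound 3 to compound 4 (0.74 log units; beyond the scatter).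

For compound 4 the estimated value is 12000 nM, with an expected range of 1000 nM to 80000 nM.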

Compound 4, half-maximal inhibitory concentration: 2600 nM
Beside the measured number, compound 4's estimate is 4.6-fold (0.66 log units) above it, within the range that was stated.
By their numbers in this assay, from the lowest: compound 1; then compound 4; then compounds 2 and 3 (each within the scatter of the next).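

In this assay, this position proves sensitive to more than the ring's substituent: compound 2 and compound 3 lie within the scatter of each other, yet 2-phenylethenyl, which keeps the carbon-only aromatic ring and adds a double bond outside it, gives a 25-fold lower number from compound 3 to compound 4 (1.40 log units; beyond the scatter) and a 25-fold lower number from compound 2 to compound 4 (1.40 log units; beyond the scatter) as large steps. Even this gain leaves a wide gap to the chain without a ring, with a 130-fold higher number from compound 1 to compound 4 (2.11 log units; beyond the scatter) still beyond the scatter. Nothing available here explains why these steps are so large.

The compounds shown leave open whether the double bond itself matters or only the greater length of the group, which 2-phenylethyl could help to separate. They also leave open how the chain of compound 1 would compare with 2-phenylethynyl or a longer chain such as hex-1-yn-1-yl.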